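Swapping the acid chain on compound 3

This account rests on a few compounds, and the source may have more. Where it says the series, first, only, none or still open, it means among the compounds named here.

Measured in a functional assay on A549 cells (Homo sapiens) for cytotoxicity, read by MTT assay, with a stated time of 72 h; on this read-out lower numbers stand for stronger inhibition and higher numbers for weaker inhibition:
- compound 1 `CC(C)(C)C1=CC(=O)C=C(NCCC(=O)O)C1=O`: 171000 nM
- compound 2 `CC(C)(C)C1=CC(=O)C=C(NCC(=O)O)C1=O`: > 200000 nM (a limit)
- compound 3 `CC1=CCC[C@H]2[C@](C)(CC3=CC(=O)C=C(N[C@@H](CC(C)C)C(=O)O)C3=O)[C@@H](C)CC[C@]12C`: 19700 nM

Of the two exact numbers, compound 3 gives the lower, 19700 nM, while compound 1 gives 171000 nM, a gap beyond the usual scatter. That gap mixes a change of core with a change of chain, so it does not isolate either one.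

The next structure is compound 4 `CC1=CCC[C@H]2[C@](C)(CC3=CC(=O)C=C(NCCC(=O)O)C3=O)[C@@H](C)CC[C@]12C`, which keeps the core of compound 3. The change is this: 2-carboxyethyl in place of 1-carboxy-3-methylbutyl on an amine nitrogen. In words, 2-carboxyethyl stands in place of 1-carboxy-3-methylbutyl on an amine nitrogen, and compound 4 thus carries the same chain as compound 1.

For the measured compounds named here, the one measured step between acid chains is an at least 1.1-fold higher number from compound 1 to compound 2 (0.06 log units; that floor lies within the scatter). It is a different swap and only a floor, so it guides weakly. Compound 2 gives only a limit, > 200000 nM.

Going by the values given here, with compound 1 at 171000 nM as the only number for this chain, a modest rise is expected in this assay. The expected change is a 1.5-fold higher number from compound 3 to compound 4 (0.18 log units; within the scatter). For compound 4 the estimated value is 30000 nM, with an expected range of 10000 nM to 90000 nM.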

Compound 4, half-maximal inhibitory concentration: 26900 nM
Estimate against measurement, compound 4: 1.1-fold (0.05 log units) above; the range from low to high includes it.
By their numbers in this assay, from the lowest: compounds 3 and 4 (each within the scatter of the next); then compound 1. At a limit, above all of these: compound 2.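

In this assay, the step at the amine nitrogen is a 1.4-fold higher number from compound 3 to compound 4 (0.14 log units; within the scatter), so 2-carboxyethyl and 1-carboxy-3-methylbutyl cannot be told apart on the shared core, even though the swap gives up a defined stereocentre along with the larger chain. For the compounds shown here, compound 4 also completes a comparison the earlier compounds lacked: it carries the same chain as compound 1, so the two differ only in the core, and compound 4 gives 26900 nM, whereas compound 1 gives 171000 nM, which places the lower number with the core of compound 4 rather than with a chain change. Nothing measured here explains why the chain swap leaves the number within the scatter or why the core matters for this pair.

From the compounds shown here alone, all four compounds carry a carboxylic acid on this nitrogen, so it remains open whether the same tolerance would hold for an ester, an amide or an amine at the end of the chain. Going by these compounds, it also remains open how a longer chain, or a carboxymethyl chain on the core of compound 3, would read in this assay.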